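A few compounds are considered here, and "the series" means these few. Any claim that something is new, unique, unknown or untested is made for them only; others in the source may bear on it.

Measured in an ADME assay on microsomes from liver (Rattus norvegicus) for metabolic stability, read by LC-MS, using NADPH, at 37 degrees C; a higher number here means that the compound lasts longer, a lower number that the compound disappears faster:
- compound 1 `CC[C@@H]1C[C@H](CC)CN(CCCNC(=O)C2CCN(Cc3nc(-c4ccccc4C)oc3C)CC2)C1`: 0.0917 h
- compound 2 `Cc1oc(-c2ccc(Cl)cc2)nc1CN1CCC(C(=O)NCCCN2C[C@H](C)C[C@H](C)C2)CC1`: > 0.5 h (a limit of the assay, not a number)
- compound 3 `Cc1oc(-c2c(F)cccc2F)nc1CN1CCC(C(=O)NCCCN2C[C@H](C)C[C@H](C)C2)CC1`: 0.35 h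

Compound 3, at 0.35 h, holds the higher of the two actual numbers, and compound 1 lies lower, beyond the scatter. Compound 2 is reported only as a limit, > 0.5 h.

The change leading to compound 4 `CC[C@@H]1C[C@H](CC)CN(CCCNC(=O)C2CCN(Cc3nc(-c4c(F)cccc4F)oc3C)CC2)C1` is 3,5-diethylpiperidin-1-yl in place of 3,5-dimethylpiperidin-1-yl on a saturated chain carbon, three bonds along the chain from an amide-type nitrogen, which puts 3,5-diethylpiperidin-1-yl in place of 3,5-dimethylpiperidin-1-yl. Going by the values given here, the only measured step, an at least 1.4-fold lower number from compound 2 to compound 3 (0.15 log units; that floor lies within the scatter), concerns the aromatic group and leaves the piperidine untouched, so it says little here. The closest guide is compound 1, which carries the same 3,5-diethylpiperidin-1-yl and stands at 0.0917 h, although its aromatic group differs as well. On that single comparison, a fall in this assay is expected, of a size probably just beyond the scatter, with an estimated 2.3-fold lower number from compound 3 to compound 4 (0.37 log units; beyond the scatter). Compound 4 is expected at 0.15 h, with an estimated range of 0.07 h to 0.3 h.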

Compound 4, half-life: 0.065 h
Compound 4: middle estimate off by 2.3-fold (0.36 log units), on the high side; the whole stated range lies above it.
By their numbers in this assay, from the lowest: compounds 4 and 1 (each within the scatter of the next); then compound 3. At a limit, above all of these: compound 2.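

In this assay, going by these compounds alone, putting 3,5-diethylpiperidin-1-yl in place of 3,5-dimethylpiperidin-1-yl, on a saturated chain carbon, three bonds along the chain from an amide-type nitrogen, gives a 5.4-fold lower number from compound 3 to compound 4 (0.73 log units; beyond the scatter), with the rest of the structure held the same, a comparison the earlier compounds did not offer. With 3,5-diethylpiperidin-1-yl present, exchanging the aromatic group leaves no readable difference, since 2,6-difluorophenyl in place of 2-methylphenyl gives a 1.4-fold lower number from compound 1 to compound 4 (0.15 log units; within the scatter). Nothing in the data shown accounts for the fall at the piperidine.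

Going by these compounds, how an unsubstituted piperidine or a morpholine would behave at this place remains open. On these data alone, compound 2 gives > 0.5 h, which is a limit of the assay, and how its 4-chlorophenyl behaves with 3,5-diethylpiperidin-1-yl also remains open.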